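The source may report more compounds than this note shows. Statements on the series, on what has been measured and on what is new or still open speak of the compounds shown alone.

Of the compounds shown here, three have so far been tested in a functional assay on PC-3 cells (Homo sapiens) for inhibition, read by MTT assay, with a stated time of 48 h (a higher number here means a weaker inhibitor, a lower number a stronger inhibitor), and every one of them sits at the same boundary. Compound 1 `O=Cc1cccc(OCc2cn(Cc3ccccc3)nn2)c1` carries the aryl ether fragment with an aldehyde and lacks the fused core; in this assay compound 1 gives only a limit, > 50000 nM. Compound 2 `O=C1Nc2ccc(Cl)cc2/C1=C/c1cccc(OCc2cn(Cc3ccccc3)nn2)c1` joins that fragment to the chloro-bearing fused core; in this assay compound 2 likewise reaches no number, only the limit > 50000 nM. Compound 3 `O=C1Nc2cc(Cl)ccc2/C1=C\c1cccc(OCc2cn(Cc3ccccc3)nn2)c1` is another arrangement of the same pieces; in this assay compound 3 again returns a limit, > 50000 nM. Compound 2 therefore stands nowhere above the floor of the data, and the two further values are limits as well (the limit of > 50000 nM in this assay, at which 3 of the 3 values shown sit).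

Compound 4 `O=C1Nc2ccc(Br)cc2/C1=C/c1cccc(OCc2cn(Cc3ccccc3)nn2)c1` differs from compound 2 by bromo in place of chloro on an aromatic carbon. Among the measured compounds shown here, no step between two measured compounds is available to size such a change. Since compound 2 reaches only the limit > 50000 nM, nothing in the data points to a gain. The step from compound 2 to compound 4 is expected to be a step that the limit leaves unreadable from compound 2 to compound 4, nothing beyond the scatter. Compound 4 is expected to give about 60000 nM, within 20000 nM to 200000 nM, most probably reported once more as a limit rather than a number.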

Compound 4, half-maximal inhibitory concentration: > 50000 nM
Compound 4: a limit, no number; the forecaster's own chance of this, stated with the estimate: 85%; the middle value does not contradict the limit.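

Compound 4, like compound 2, gives only a limit in this assay, so no step can be read for bromo in place of chloro on an aromatic carbon: the limit of > 50000 nM in this assay, at which 4 of the 4 values shown sit.

The compounds shown leave open which structural change, if any, would yield a true number in this assay.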